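Moving the substituent on the aryl piperazine of a xanthine series

The source may report more compounds than this note shows. Statements on the series, on what has been measured and on what is new or still open speak of the compounds shown alone.

Compound 3 `CCCn1c(=O)[nH]c2nc(-c3ccc(S(=O)(=O)N4CCN(c5ccc(C)cc5)CC4)cc3)[nH]c2c1=O` is the shared core bearing a 4-methylphenyl on the ring nitrogen; in an assay on CHO cells for displacement of a labelled ligand from adenosine receptor A1 (Homo sapiens), read by scintillation counting, with a stated time of 90 min, tested at 1 uM, in the presence of a further agent that is not named here (on this read-out higher numbers stand for more inhibition at the one concentration tested (going by the name of the read-out) and lower numbers for less inhibition), compound 3 gives 12%, second highest of the three numbers, close to compound 1 `CCCn1c(=O)[nH]c2nc(-c3ccc(S(=O)(=O)N4CCN(c5ccc(Br)cc5)CC4)cc3)[nH]c2c1=O` with 13% and clearly above compound 2 `CCCn1c(=O)[nH]c2nc(-c3ccc(S(=O)(=O)N4CCN(c5cccc(Br)c5)CC4)cc3)[nH]c2c1=O` with -1%. Compound 4 `CCCn1c(=O)[nH]c2nc(-c3ccc(S(=O)(=O)N4CCN(c5cccc(F)c5)CC4)cc3)[nH]c2c1=O` differs from compound 3 by 3-fluorophenyl in place of 4-methylphenyl on an amine nitrogen in a ring. Within the data shown here, two measured steps bear on this: a number 14 percentage points lower from compound 1 to compound 2 (beyond the scatter) and a number 13 percentage points higher from compound 2 to compound 3 (beyond the scatter), both showing that a 3-bromophenyl sits lower than a 4-bromophenyl or a 4-methylphenyl. A 3-fluorophenyl resembles the 3-bromophenyl of compound 2 more than the 4-methylphenyl of compound 3, so a modest drop is expected, a number 9 percentage points lower from compound 3 to compound 4 (within the scatter). Compound 4 is therefore estimated at 3%, within -9% to 15%.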

Compound 4, a percentage reported as inhibition, at one concentration (the size of the read-out at that concentration, not a potency): 34%
For compound 4 the middle estimate is 31 percentage points below the measured one; measured number above the stated range.
By their numbers in this assay, from the lowest: compound 2; then compounds 3 and 1 (each within the scatter of the next); then compound 4.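

Fluoro in place of bromo on the same aromatic carbon gives a number 35 percentage points higher from compound 2 to compound 4 (beyond the scatter) in this assay, so two phenyl groups named with the same 3 can sit far apart on this ring nitrogen. The 3-fluorophenyl also exceeds both groups named with a 4, with a number 22 percentage points higher from compound 3 to compound 4 (beyond the scatter) and a number 21 percentage points higher from compound 1 to compound 4 (beyond the scatter), which makes compound 4 the highest of the four. No measurement shown accounts for this gain.

Still open, on these data alone, is where a 4-fluorophenyl would fall, which would separate the fluorine from its place on the ring. A 3-chlorophenyl would show whether compound 4 stays alone among the halogens.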